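The source may hold more compounds than are shown below. What is called first, only, known or untested is meant among the compounds shown, and "the series" means these compounds.

Compound 1 `CC[C@H](C)C(N)c1cc(C(F)(F)F)ccc1N1CCN(C(=O)CCc2ccc(Cl)cc2Cl)CC1` gives 75 nM in an assay on HEK293 cells for displacement of a labelled ligand from Melanocortin receptor 4 (Homo sapiens); on this read-out higher numbers stand for weaker inhibition and lower numbers for stronger inhibition. That is the lowest of the three numbers in hand, though not by a margin that sets it apart from compound 2 `CCC(C)[C@H](N)c1cc(C(F)(F)F)ccc1N1CCN(C(=O)CCc2ccc(Cl)cc2)CC1`, which gives 86 nM in this assay, a result within the scatter of compound 1. Compound 3 `Cc1cccc(CCC(=O)N2CCN(c3ccc(C(F)(F)F)cc3[C@@H](N)CC(C)C)CC2)c1` gives 2100 nM in this assay, a number far beyond the scatter above the other two. Compound 4 `CCC(C)[C@H](NC(=O)OC)c1cc(C(F)(F)F)ccc1N1CCN(C(=O)CCc2ccc(Cl)cc2Cl)CC1` differs from compound 1 in one place: 1-((methoxycarbonyl)amino)-2-methylbutyl in place of 1-amino-2-methylbutyl on an aromatic carbon. Among the compounds with values here, no measured pair shows a change of this kind, so nothing in hand sizes the step directly. The step from compound 1 to compound 4 is expected to go toward a higher number, moderately beyond the scatter, as a 4.0-fold higher number from compound 1 to compound 4 (0.60 log units; beyond the scatter). Compound 4 is therefore expected to give about 300 nM in this assay, within a range of 80 nM to 1500 nM.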

Compound 4, inhibition constant: 2400 nM
Estimate against measurement, compound 4: 8.0-fold (0.90 log units) below; the measured number lies above the stated range.
By their numbers in this assay, from the lowest: compounds 1 and 2 (each within the scatter of the next); then compounds 3 and 4 (each within the scatter of the next).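

In this assay, within the data shown here, the change at this aromatic carbon, ortho to a large group, is the first measured step at this position, and it is large: 1-((methoxycarbonyl)amino)-2-methylbutyl in place of 1-amino-2-methylbutyl gives a 32-fold higher number from compound 1 to compound 4 (1.51 log units; beyond the scatter), well beyond the scatter. The position therefore does not accept this change to the amino group without a large rise in the number. Nothing in hand accounts for the size of this step.

With a single change at this position, the step cannot be assigned to the added methoxycarbonyl group as a whole or to any one part of it. As far as these compounds go, whether an acetyl group or a single methyl group on the same nitrogen would keep the number near that of compound 1 remains open.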